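The source may report more compounds than this note shows. Statements on the series, on what has been measured and on what is new or still open speak of the compounds shown alone.

Compounds measured in a functional assay on SR cells (Homo sapiens) for inhibition, read by sulforhodamine B assay, with a stated time of 48 h; a higher number here means a weaker inhibitor of growth, a lower number a stronger inhibitor of growth:
Compound 1 `COc1cc(-c2cc(/C=C/C(=O)c3ccc(N)cc3)[nH]n2)cc(OC)c1OC` gives 2750 nM.
Compound 2 `COc1ccc(C(=O)/C=C/c2cc(-c3cc(OC)c(OC)c(OC)c3)n[nH]2)cc1OC` gives only a limit, > 100000 nM.
Compound 3 `COc1ccc(C(=O)/C=C/c2cc(-c3cc(OC)c(OC)c(OC)c3)n[nH]2)cc1` gives 23900 nM.

Compound 2 is the weakest point here, standing at the limit of > 100000 nM in this assay, at which 1 of the 3 values shown sits, rather than at a number. Compound 4 `COc1cc(C(=O)/C=C/c2cc(-c3cc(OC)c(OC)c(OC)c3)n[nH]2)cc(OC)c1OC` differs from it by methoxy in place of hydrogen on an aromatic carbon. The step that bears on this is the one running the other way, an at least 4.1-fold lower number from compound 2 to compound 3 (0.62 log units; beyond the scatter), where taking a methoxy off this ring made growth inhibition stronger; putting one on is therefore expected to go the opposite way or show no measurable change. The large step of an at least 36-fold higher number from compound 1 to compound 2 (1.56 log units; beyond the scatter) also shows this end of the molecule already far from compound 1. Compound 4 is therefore expected to stay at the limit, with a step that the limit leaves unreadable from compound 2 to compound 4 and an estimate of 200000 nM (range 60000 nM to 800000 nM).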

Compound 4, concentration for total growth inhibition: > 100000 nM
Compound 4: only a limit was reported; the forecaster's own chance of this, stated with the estimate: 85%; the middle value does not contradict the limit.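

Going by these compounds alone, compound 2 and compound 4 both give only a limit, not a number, so no step between them can be read: the limit of > 100000 nM in this assay, at which 2 of the 4 values shown sit. The compounds shown leave open whether methoxy in place of hydrogen here changes growth inhibition at all.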